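The source may report more compounds than this note shows. Statements on the series, on what has been measured and on what is new or still open speak of the compounds shown alone.

In an ADME assay on MT4 cells (Homo sapiens) for cytotoxicity, read by MTT assay, with a stated time of 5 days (on this read-out lower numbers stand for higher toxicity in this test and higher numbers for lower toxicity in this test), compound 1 `COc1cc2nc(Nc3ccc(C#N)cc3)nc(Nc3c(C)cc(/C=C/C#N)cc3C)c2cc1OC` gives a measured number, 10200 nM. Compound 2 `COc1cc2nc(SCC(=O)Nc3ccc(C#N)cc3)nc(Nc3c(C)cc(/C=C/C#N)cc3C)c2cc1OC` gives only a limit, > 227000 nM. Compound 3 `COc1cc2nc(SCC(=O)Nc3ccc([N+](=O)[O-])cc3)nc(Nc3c(C)cc(/C=C/C#N)cc3C)c2cc1OC` also gives only a limit, > 219000 nM. Within the data shown here, compound 3 therefore has no exact place on the numbers, and the only other compound in that position is compound 2.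

The next change leads to compound 4 `COc1cc2nc(SCC(=O)Nc3ccc(F)cc3)nc(Nc3c(C)cc(/C=C/C#N)cc3C)c2cc1OC`: fluoro in place of nitro on an aromatic carbon. In words, fluoro takes the place of nitro on an aromatic carbon, para to a large group. Among the measured compounds shown here, the one measured step that bears on this change is a step that the two limits leave unreadable from compound 2 to compound 3, which also replaces one group with another at this place. Its size cannot be read, so it gives no measured size to carry forward. On that evidence, no step beyond the usual scatter is expected in this assay, and no direction can be given. The expected step is a step that the limit leaves unreadable from compound 3 to compound 4. Compound 4 is estimated at 230000 nM, with an expected range from 90000 nM to 300000 nM.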

Compound 4, half-maximal cytotoxic concentration: >= 150000 nM
Compound 4 gave a limit, no number; the forecaster's own chance of this, stated with the estimate: 80%; the middle value lies beyond the limit too.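

In this assay compound 4 gives only a limit: the limit of >= 150000 nM in this assay, at which 1 of the 4 values shown sits. With fluoro on this aromatic carbon, para to a large group, the read-out is again a limit, as it was with cyano in compound 2 and nitro in compound 3, so three different groups at this place have now given no exact number. Among these compounds, the one step that can be read is an at least 14-fold higher number from compound 1 to compound 4 (1.16 log units; beyond the scatter), and it reflects the exchange of a whole group rather than the fluoro change alone; the steps among compound 2, compound 3 and compound 4 cannot be read.

The compounds shown leave open whether any group at this place would give an exact number in this assay. They also leave open whether an amine or a carboxylic acid there would again give only a limit.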